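This account rests on a few compounds, and the source may have more. Where it says the series, first, only, none or still open, it means among the compounds named here.

Compound 2 has the structure `COc1ccc(CN(CC#N)Cc2ccccc2)cc1`. Among the compounds with values here, in an assay on HEK293 cells for binding affinity to Substance-K receptor (Rattus norvegicus), read by FRET, tested at 10 uM (a higher number here means more inhibition at the concentration tested (going by the name of the read-out), a lower number less inhibition), compound 2 gives 0%, which places it level with the only other compound measured here, compound 1, whose structure is `N#CCN(Cc1ccccc1)Cc1ccc(Cl)cc1`. In this assay compound 1 gives 0%, and the step of no change at the digits printed from compound 1 to compound 2 (within the scatter) shows that swapping methoxy in place of chloro on an aromatic carbon left the read-out unchanged within the scatter.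

The next compound, compound 3, has the structure `N#CCN(Cc1ccccc1)Cc1ccc(C(F)(F)F)cc1`. Measured against compound 2 the change is trifluoromethyl in place of methoxy on an aromatic carbon. Within the data shown here, the one step measured so far, no change at the digits printed from compound 1 to compound 2 (within the scatter), exchanged one small group for another at the same aromatic carbon and produced no movement, with both compounds sitting at the bottom of the scale. A trifluoromethyl in place of methoxy on an aromatic carbon is a change of the same kind and at the same place, and nothing measured here points to any effect of such a swap.

Compound 3 is therefore expected to move by no change at the digits printed from compound 2 to compound 3 (within the scatter), that is, to show no change beyond the scatter. For compound 3 the estimate in this assay is 0%, with a range from -10% to 15%.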

Compound 3, a percentage reported as inhibition, at one concentration (the size of the read-out at that concentration, not a potency): 0%
The estimate for compound 3 equals the measured number at the digits printed; measured number inside the range.
By their numbers in this assay, from the lowest: compounds 1, 2 and 3 (each within the scatter of the next).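

Across this assay, trifluoromethyl gives no change at the digits printed from compound 2 to compound 3 (within the scatter) when it replaces methoxy and no change at the digits printed from compound 1 to compound 3 (within the scatter) when it replaces chloro, so three different groups on this aromatic carbon, para to a large group, now give the same reading. This swap is also a larger change in what is counted than a simple exchange of names suggests: methoxy has 2 heavy atoms and 1 hydrogen-bond acceptor, trifluoromethyl has 4 heavy atoms and 0 hydrogen-bond acceptors, yet compound 3 gives 0% in this test, like the others. Within the data shown here, with all three compounds at the bottom of the scale, the result shows only that none of these groups brings a detectable inhibition, and nothing measured here explains that.

Since no compound shown gives a reading above zero, it remains open whether any group at this position can move the number at all, for example an amine or a carboxylic acid. Also open, as far as these compounds go, is whether changes elsewhere on the shared core would do so, such as a longer chain carrying the nitrile or an amide in place of the nitrile.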